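From cyano to ethoxy: a small expected step

This account rests on a few compounds, and the source may have more. Where it says the series, first, only, none or still open, it means among the compounds named here.

Values so far in an ADME assay on HepG2 2.2.15 cells (Homo sapiens) for cytotoxicity (on this read-out higher numbers stand for lower toxicity in this test and lower numbers for higher toxicity in this test), for three compounds:

Compound 1 `CCC(=O)OCCc1c(-c2ccccc2Cl)c2cc(Cl)ccc2[nH]c1=O` gives 95000 nM
Compound 2 `CCCC(=O)OCCc1c(-c2ccccc2Cl)c2cc(Cl)ccc2[nH]c1=O` gives 52000 nM
Compound 3 `N#CCC(=O)OCCc1c(-c2ccccc2Cl)c2cc(Cl)ccc2[nH]c1=O` gives 100000 nM

Compound 3 stands at 100000 nM and is not separated from the other two values. The two measured steps that change the group on this chain carbon are a 1.1-fold higher number from compound 1 to compound 3 (0.02 log units; within the scatter) and a 1.9-fold higher number from compound 2 to compound 3 (0.28 log units; within the scatter) in this small set. The third step is a 1.8-fold lower number from compound 1 to compound 2 (0.26 log units; within the scatter) and it too stays small.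

The remaining compound, compound 4 `CCOCC(=O)OCCc1c(-c2ccccc2Cl)c2cc(Cl)ccc2[nH]c1=O`, differs from compound 3 by ethoxy in place of cyano on a saturated chain carbon bound to a carbonyl carbon and so carries ethoxy in place of cyano on a saturated chain carbon bound to a carbonyl carbon. For the measured compounds named here, no compound with ethoxy has been measured, so the size of this step is not known directly. All three measured steps stay within the scatter, so no step beyond the scatter is expected in this assay and no firm direction can be given.

The step expected by this estimate is a 1.4-fold lower number from compound 3 to compound 4 (0.15 log units; within the scatter) and it remains a modest one. For compound 4 the estimated value is 70000 nM with an expected range from 35000 nM to 130000 nM in this read-out.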

Compound 4, half-maximal cytotoxic concentration: 130000 nM
Compound 4: the middle estimate sits 1.9-fold (0.27 log units) below what was measured, and the stated range covers the measured number.
By their numbers in this assay, from the lowest: compounds 2, 1, 3 and 4 (each within the scatter of the next, the first and the last beyond it).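

In this assay, for the compounds shown here, the group on this saturated chain carbon bound to a carbonyl carbon now produces a step beyond the scatter for the first time, though a modest one, when ethoxy stands in place of ethyl (a 2.5-fold higher number from compound 2 to compound 4 (0.40 log units; beyond the scatter)). Ethoxy is not separated from the other two groups, since ethoxy in place of cyano (a 1.3-fold higher number from compound 3 to compound 4 (0.11 log units; within the scatter)) and ethoxy in place of methyl (a 1.4-fold higher number from compound 1 to compound 4 (0.14 log units; within the scatter)) both stay within the scatter, so the four compounds separate only at the two ends of their series, with compound 1 and compound 3 resolved from neither end. No measurement shown accounts for the single step that clears the scatter.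

The compounds shown leave open whether a longer chain such as propoxy, an amine or a carboxylic acid on this carbon would move the number further in either direction or stay within the same narrow band. They also leave open whether the difference between ethoxy and ethyl would hold on repeated measurement, given how little it clears the scatter, and whether it would appear in any read-out other than this assay.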